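The compounds below may be only part of what the source reports. "The series", "measured", "known", "first", "only" and "open" are said of these compounds alone.

Three esters of a shared core have been tested in a functional assay on MCF7 cells (Homo sapiens) for antiproliferative activity, read by sulforhodamine B assay, with a stated time of 48 h, tested at 50 uM; a lower number here means less inhibition, a higher number more inhibition at the concentration tested (going by the name of the read-out). Compound 1 `CC1=CC[C@H](C(C)C)c2cc(C)c(OC(=O)c3ccc(C)cc3)cc21` gives 65%, compound 2 `CC1=CC[C@H](C(C)C)c2cc(C)c(OC(=O)c3ccc(C(F)(F)F)cc3)cc21` gives 40.4%, and compound 3 `CC1=CC[C@H](C(C)C)c2cc(C)c(OC(=O)c3cccc(C(F)(F)F)c3)cc21` gives 86%. Compound 3 and compound 2 hold the same atoms joined differently; the difference between the two cores is not broken down here. Compound 1 differs from compound 2 by methyl in place of trifluoromethyl on an aromatic carbon, and that gave a number 24.6 percentage points higher from compound 2 to compound 1 (beyond the scatter). Compound 4 `CC1=CC[C@H](C(C)C)c2cc(C)c(OC(=O)c3cccc(C)c3)cc21` is not yet measured; it differs from compound 3 by methyl in place of trifluoromethyl on an aromatic carbon. This is the same kind of change as the earlier one, though not the same: the place was para to a large group there and is meta to a large group here. Because compound 3 already stands at 86%, little room remains upward, so only a small step is expected, a number 6 percentage points lower from compound 3 to compound 4 (within the scatter). Compound 4 is expected to give 80%, between 55% and 97%.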

Compound 4, a percentage reported as inhibition, at one concentration (the size of the read-out at that concentration, not a potency): 54.9%
For compound 4 the middle estimate is 25.1 percentage points above the measured one, outside the stated range (below it).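

In this assay, methyl in place of trifluoromethyl gives a number 31.1 percentage points lower from compound 3 to compound 4 (beyond the scatter), so the change does not carry over from the earlier pair, where the step went the other way: the same change on two cores in this assay, a number 24.6 percentage points higher (beyond the scatter) from compound 2 to compound 1 and a number 31.1 percentage points lower (beyond the scatter) from compound 3 to compound 4, 55.7 percentage points apart, beyond the scatter of two such steps

Moving the methyl alone, with 3-methylphenyl in place of 4-methylphenyl, gives a number 10.1 percentage points lower from compound 1 to compound 4 (beyond the scatter), so the position on the ring also counts among these compounds. With one pair for each position and a single tested concentration, this shows that the step depends on where the change is made, but not why, and it gives no rule for other groups.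

The compounds shown leave open how an amine, a carboxylic acid or a longer chain would read on this ring. They also leave open whether an amide could stand in place of the ester.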